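A few compounds are considered here, and "the series" means these few. Any claim that something is new, unique, unknown or untested is made for them only; others in the source may bear on it.

Measured so far in an ADME assay on L132 cells (Homo sapiens) for cytotoxicity, read by MTT assay, with a stated time of 48 h; on this read-out lower numbers stand for stronger inhibition and higher numbers for weaker inhibition:
compound 1 `C/C(=C\CC/C(C)=C/CC[C@@H]1[C@@]2(C)CCC(=O)C(C)(C)[C@H]2CC[C@@]1(C)O)CC/C=C(\C)C(=O)OCc1cn(-c2ccccc2Cl)nn1` gives > 150000 nM, a limit of the assay rather than a number.
compound 2 `C/C(=C\CC/C(C)=C/CC[C@@H]1[C@@]2(C)CCC(=O)C(C)(C)[C@H]2CC[C@@]1(C)O)CC/C=C(\C)C(=O)OCc1cn(-c2ccccc2C(F)(F)F)nn1` gives > 150000 nM, again a limit.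
compound 3 `C/C(=C\CC/C(C)=C/CC[C@@H]1[C@@]2(C)CCC(=O)C(C)(C)[C@H]2CC[C@@]1(C)O)CC/C=C(\C)C(=O)OCc1cn(C[C@@H]2O[C@H](n3ccc(=O)[nH]c3=O)[C@H]3OC(C)(C)O[C@H]32)nn1` gives > 150000 nM, also a limit.

Compound 2 therefore stands where every value of the series stands: at the limit of > 150000 nM in this assay, at which 3 of the 3 values shown sit. Within the data shown here, no compound has a number below it, so no order among the three can be read. Among the measured compounds shown here, the one single-point change within the measured set, a step that the two limits leave unreadable from compound 1 to compound 2, gives no size at all, as both ends are limits.

Compound 4 `C/C(=C\CC/C(C)=C/CC[C@@H]1[C@@]2(C)CCC(=O)C(C)(C)[C@H]2CC[C@@]1(C)O)CC/C=C(\C)C(=O)OCc1cn(-c2ccc(Br)cc2)nn1` is the next member. Its change from compound 2 is 4-bromophenyl in place of 2-(trifluoromethyl)phenyl on an aromatic nitrogen. For the measured compounds named here, the only measured step that bears on it is the unreadable one from compound 1 to compound 2; no step with a readable size exists in this assay. Given that all three shown values sit at the limit of > 150000 nM in this assay, at which 3 of the 3 values shown sit, the expectation for compound 4 is no step beyond the scatter, a step that the limit leaves unreadable from compound 2 to compound 4, with a good chance that the assay again reports only a limit. Compound 4 is expected at 200000 nM, with a range of 100000 nM to 500000 nM.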

Compound 4, half-maximal inhibitory concentration: > 150000 nM
Compound 4 gave a limit, no number; the forecaster's own chance of this, stated with the estimate: 85%; the middle value lies beyond the limit too.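

In this assay compound 4 gives only a limit, as compound 1 and compound 2 do, so no new step can be read between these compounds. The compounds shown leave open whether any change to the group on the aromatic nitrogen would give a measurable number.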